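This account rests on a few compounds, and the source may have more. Where it says the series, first, only, none or still open, it means among the compounds named here.

Values so far in a physicochemical assay for solubility, read by HPLC, in phosphate buffer, measured as kinetic solubility, with a stated time of 1 h, at pH 7.4, tested at 250 uM; a higher number here means a more soluble compound, a lower number a less soluble compound:

- Compound 1 `O=C(NCCCCc1ccccc1)n1c2c(oc1=O)CNCC2` reads 230000 nM
- Compound 2 `CC(C)CN1CCC(c2ccc3c(c2)oc(=O)n3C(=O)NCCCCc2ccccc2)CC1` reads < 1000 nM as a limit

Compound 2 gives only a limit, (the limit of < 1000 nM in this assay, at which 1 of the 2 values shown sits), and no number. Going by the values given here, compound 1 is the only compound with a number so far. Among the compounds with values here, no measured pair differs in one place, so nothing measured sizes the change that comes next.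

Compound 3 `CCN1CCC(c2ccc3c(c2)oc(=O)n3C(=O)NCCCCc2ccccc2)CC1` has methyl in place of isopropyl on a saturated chain carbon bound to an amine nitrogen in a ring, which, cut one bond further out, reads isobutyl to ethyl: methyl in place of isopropyl on a saturated chain carbon bound to an amine nitrogen in a ring. The rest of compound 2 stays as it is.

The expectation starts from compound 2, whose limit is < 1000 nM in this assay. A modest rise is expected, with compound 3 staying much nearer to compound 2 than to compound 1, and a second reading at the limit remains possible. The estimated step of an at least 3.0-fold higher number from compound 2 to compound 3 (0.47 log units; beyond the scatter) is upward but small against that distance. For compound 3 the expected value is 3000 nM, with an estimated range of 800 nM to 30000 nM.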

Compound 3, solubility: 198000 nM
For compound 3 the middle estimate is 66-fold (1.82 log units) below the measured one; measured number outside the range, above it.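

In this assay, going by these compounds alone, methyl in place of isopropyl, on a saturated chain carbon bound to an amine nitrogen in a ring, gives an at least 190-fold higher number from compound 2 to compound 3 (2.29 log units; beyond the scatter) and so puts the first size on a change at this place, a large step well beyond the scatter. The change itself is confined to a simple alkyl group: 3 heavy atoms leave and 1 enters, with no ring, no hydrogen-bond donor or acceptor and no net charge on either side, and the rest of the molecule stays as it is. The printed step is a lower bound and not a full size because compound 2 has only a limit and no number: the limit of < 1000 nM in this assay, at which 1 of the 3 values shown sits.

The true size of the step and the reason for it stay open, as one pair at one place supplies neither. Also unsettled is how the read-out behaves with other groups at this place, such as a propyl chain, a cyclopropylmethyl group or a 2-hydroxyethyl chain, and whether the same change carries over to a different core.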